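Fluoro to hydrogen on the pyridin-2-yl of compound 2

The source may report more compounds than this note shows. Statements on the series, on what has been measured and on what is new or still open speak of the compounds shown alone.

Compound 2 `O=C(CN1CCN(c2ccc(F)cn2)CC1)Nc1nc2c(s1)CCCC2` gives 600 nM in an assay on isolated protein for inhibition of long-chain fatty acid transport protein 1 (Mus musculus), read by scintillation counting, with a stated time of 20 min (a higher number here means a weaker inhibitor, a lower number a stronger inhibitor), the lowest of the two numbers in the set so far. Compound 3 `O=C(CN1CCN(c2ccc(F)cc2)CC1)Nc1nc2c(s1)CCCCC2` gives 2000 nM in this assay, a clearly higher number. For compound 1 `O=C(CN1CCN(c2cccc(F)c2)CC1)Nc1nc2c(s1)CCCC2` this assay reports only > 10000 nM, which is a limit of the assay and not a number (the limit of > 10000 nM in this assay, at which 1 of the 3 values shown sits). Among the compounds with values here, the only step measured between compounds differing in one place is an at least 16-fold lower number from compound 1 to compound 2 (1.22 log units; beyond the scatter), and it exchanges the whole aryl group on the ring amine rather than a single substituent.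

Compound 4 `O=C(CN1CCN(c2ccccn2)CC1)Nc1nc2c(s1)CCCC2` differs from compound 2 by hydrogen in place of fluoro on an aromatic carbon. Within the data shown here, no measured step in this set removes a fluorine alone, so the step from compound 1 to compound 2, large as it is, bears on the present change only in that both touch the aryl group on the ring amine; it gives no direct read on the fluorine by itself. The expectation is therefore a modest step, if any, toward a somewhat higher number in this assay, estimated as a 1.7-fold higher number from compound 2 to compound 4 (0.22 log units; within the scatter). Compound 4 is expected to give about 1000 nM in this assay, with a likely range from 400 nM to 2500 nM.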

Compound 4, half-maximal inhibitory concentration: 4900 nM
Estimate against measurement, compound 4: 4.9-fold (0.69 log units) below; the whole stated range lies below it.
By their numbers in this assay, from the lowest: compound 2; then compound 3; then compound 4. At a limit, above all of these: compound 1.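

Hydrogen in place of fluoro on the pyridin-2-yl group gives, in this assay, an 8.2-fold higher number from compound 2 to compound 4 (0.91 log units; beyond the scatter), so this one position, para to a large group, carries a clear effect of its own that the earlier exchange of the whole aryl group could not separate out. The large step, an at least 16-fold lower number from compound 1 to compound 2 (1.22 log units; beyond the scatter), therefore cannot be credited to the change of aryl group without the fluoro, and compound 2 keeps the lowest number in the set only with the fluoro in place. With the fluoro gone, the exchange of 3-fluorophenyl for pyridin-2-yl reads as an at least 2.0-fold lower number from compound 1 to compound 4 (0.30 log units; that floor lies within the scatter), and this is only a floor because compound 1 stands at a limit and not at a number: the limit of > 10000 nM in this assay, at which 1 of the 4 values shown sits.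

The compounds shown leave open whether chloro, methyl or methoxy at this place would hold the number as fluoro does, or whether only fluoro does so. They also leave open whether the fluoro step on the pyridin-2-yl group carries over to the core of compound 3, and nothing here tells why the fluoro matters.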